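Removing a Chain Hydroxy Group: Compound 1 to Compound 3

A few compounds are considered here, and "the series" means these few. Any claim that something is new, unique, unknown or untested is made for them only; others in the source may bear on it.

Compound 1, `COc1ccccc1N1CCN(CC(O)CCn2cc(-c3ccc4ncccc4c3)nn2)CC1`: > 3000 nM
Compound 2, `OC(CCn1cc(-c2ccc3ncccc3c2)nn1)CN1CCN(c2cccc(Cl)c2Cl)CC1`: "not determined" (no result reported)

In an assay on HEK293 cells for displacement of a labelled ligand from D(4) dopamine receptor (Homo sapiens), read by scintillation counting, with a stated time of 1 h (a higher number here means a weaker inhibitor, a lower number a stronger inhibitor), compound 1 gives > 3000 nM, which is a limit of the assay and not a number. For compound 2 the entry in this assay reads "not determined" (no result reported). Within the data shown here, compound 1 thus stands only at the limit of > 3000 nM in this assay, at which 1 of the 2 values shown sits, with no measured step to any other compound. Compound 3, `COc1ccccc1N1CCN(CCCCn2cc(-c3ccc4ncccc4c3)nn2)CC1`, differs from compound 1 by hydrogen in place of hydroxy on a saturated chain carbon bound to two saturated chain carbons. Among the measured compounds shown here, with no measured step to guide the size, the change is expected to move the inhibition constant in this assay little, not beyond the usual scatter. Compound 3 is therefore estimated at 4000 nM, between 1500 nM and 15000 nM. The expected step is a step that the limit leaves unreadable from compound 1 to compound 3.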

Compound 3, inhibition constant: 269 nM
Estimate against measurement, compound 3: 15-fold (1.17 log units) above, outside the stated range (below it).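

In this assay, hydrogen in place of hydroxy on a saturated chain carbon bound to two saturated chain carbons gives an at least 11-fold lower number from compound 1 to compound 3 (1.04 log units; beyond the scatter). This shows that the position is sensitive to this change and that the hydroxy-bearing compound 1 is the weaker of the pair. The true size of the step stays unknown, as compound 1 gives a limit of the assay and not a number: the limit of > 3000 nM in this assay, at which 1 of the 3 values shown sits.

The compounds shown leave open whether a methoxy group, a fluorine atom or an amine on this carbon would give a number closer to that of compound 1 or compound 3. They also leave open whether a longer chain would keep the number of compound 3.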